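A few compounds are considered here, and "the series" means these few. Any claim that something is new, unique, unknown or untested is made for them only; others in the source may bear on it.

Compound 2 `NC(=O)c1c(NC(=O)c2ccccc2C(F)(F)F)sc2c1CCN(C(=S)Nc1ccccc1Cl)C2` is one of three closely related compounds tested in a functional assay on HL-60 cells (Homo sapiens) for antiproliferative activity, with a stated time of 24 h; a lower number here means a stronger inhibitor, a higher number a weaker inhibitor. In this assay compound 2 gives 17600 nM. This places it second highest among the three numbers. Its nearest neighbour is compound 1 `NC(=O)c1c(NC(=O)c2ccccc2)sc2c1CCN(C(=S)Nc1ccccc1Cl)C2`, which in this assay gives 13800 nM, and the step of a 1.3-fold higher number from compound 1 to compound 2 (0.11 log units; within the scatter) is within the scatter. The furthest is compound 3 `NC(=O)c1c(NC(=O)c2ccncn2)sc2c1CCN(C(=S)Nc1ccccc1Cl)C2`, which in this assay gives 34600 nM; the step of a 2.0-fold higher number from compound 2 to compound 3 (0.29 log units; within the scatter) is within the scatter, while a 2.5-fold higher number from compound 1 to compound 3 (0.40 log units; beyond the scatter) is modest and beyond it.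

Compound 4 `NC(=O)c1c(NC(=O)c2ccccc2C(F)(F)F)sc2c1CCN(C(=S)Nc1ccccc1Br)C2` differs from compound 2 by one change: bromo in place of chloro on an aromatic carbon. Among the measured compounds shown here, none of the measured steps touches this part of the molecule; all three alter the group attached to the carbonyl carbon on the other side of the shared core. For the measured compounds named here, there is therefore no measured step that bears directly on the exchange of one halogen for another here, and the swap is small. The expectation for compound 4 in this assay is a step of a 1.1-fold lower number from compound 2 to compound 4 (0.04 log units; within the scatter), that is, no change beyond the scatter. Compound 4 is expected to give about 16000 nM, with a likely range from 7000 nM to 36000 nM.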

Compound 4, half-maximal inhibitory concentration: 25500 nM
Beside the measured number, compound 4's estimate is 1.6-fold (0.20 log units) below it; the range from low to high includes it.
By their numbers in this assay, from the lowest: compounds 1, 2, 4 and 3 (each within the scatter of the next, the first and the last beyond it).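

Among the compounds shown here, compound 4 gives the first reading on the 2-chlorophenyl side of the molecule. For the compounds shown here, all the earlier steps altered the group on the carbonyl at the other end of the shared core. In this assay, bromo in place of chloro on this aromatic carbon, ortho to a large group, gives a 1.4-fold higher number from compound 2 to compound 4 (0.16 log units; within the scatter), a step within the scatter, so this assay does not separate these two halogens at this position. No supporting measurement is available that could explain the size of this step or link it to any property of either halogen.

The compounds shown leave open whether a different kind of group at this position, such as methoxy, an amine or a carboxylic acid, or simply hydrogen in place of the halogen, would move the number beyond the scatter. They also leave open whether the same halogen exchange would give a similar step with the plain phenyl of compound 1 or the pyrimidin-4-yl of compound 3 on the carbonyl, since here it is read only with the 2-(trifluoromethyl)phenyl of compound 2.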